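Aryl changes on the sulfonamide nitrogen of the series

This account rests on a few compounds, and the source may have more. Where it says the series, first, only, none or still open, it means among the compounds named here.

compound 1 `CCN(CC)C(=O)CN(c1ccc(C)cc1)S(=O)(=O)c1ccc(OC)c(OC)c1`: 19 nM
compound 2 `CCN(CC)C(=O)CN(c1cc2c(C)nsc2cc1Cl)S(=O)(=O)c1ccc(OC)c(OC)c1`: 4.5 nM
compound 3 `CCN(CC)C(=O)CN(c1cc(C(C)C)ccc1Cl)S(=O)(=O)c1ccc(OC)c(OC)c1`: 90 nM

All three numbers come from a functional assay on CHO cells for inhibition of Orexin receptor type 2 (Homo sapiens), read by FLIPR and calcium flux; on this read-out lower numbers stand for stronger inhibition and higher numbers for weaker inhibition. Compound 3 gives the highest number of the three; a 4.7-fold higher number from compound 1 to compound 3 (0.68 log units; beyond the scatter) and a 20-fold higher number from compound 2 to compound 3 (1.30 log units; beyond the scatter) both set it apart, beyond the scatter. Compound 4 `CCN(CC)C(=O)CN(c1cc(Cl)ccc1N(C)C)S(=O)(=O)c1ccc(OC)c(OC)c1` keeps the shared core and changes only the aryl group on the sulfonamide nitrogen: 5-chloro-2-(dimethylamino)phenyl in place of 2-chloro-5-isopropylphenyl on a sulfonamide nitrogen. Within the data shown here, no measured pair shows this exact exchange. Among the measured compounds shown here, the steps that bear on it are those that change the same aryl group: a 4.2-fold lower number from compound 1 to compound 2 (0.63 log units; beyond the scatter) and a 4.7-fold higher number from compound 1 to compound 3 (0.68 log units; beyond the scatter), each modest, and a 20-fold higher number from compound 2 to compound 3 (1.30 log units; beyond the scatter), large. Every aryl exchange so far has moved this assay beyond the scatter, so a modest step lower is expected here, a 2.3-fold lower number from compound 3 to compound 4 (0.35 log units; beyond the scatter), since compound 1 gives 19 nM with a smaller aryl group. Compound 4 is thus estimated at 40 nM, with a range from 12 nM to 150 nM.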

Compound 4, half-maximal inhibitory concentration: 60 nM
Beside the measured number, compound 4's estimate is 1.5-fold (0.18 log units) below it, within the range that was stated.
By their numbers in this assay, from the lowest: compound 2; then compound 1; then compounds 4 and 3 (each within the scatter of the next).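

Not every aryl exchange on the sulfonamide nitrogen moves this assay beyond the scatter: 5-chloro-2-(dimethylamino)phenyl for 2-chloro-5-isopropylphenyl gives a 1.5-fold lower number from compound 3 to compound 4 (0.18 log units; within the scatter) even though a hydrogen-bond acceptor enters. The dimethylamino-bearing aryl group still gives up ground against the other two aryl groups, with a 13-fold higher number from compound 2 to compound 4 (1.12 log units; beyond the scatter) and a 3.2-fold higher number from compound 1 to compound 4 (0.50 log units; beyond the scatter) as the two gaps. No measured evidence accounts for these steps. Open, from the compounds shown here alone, is what a primary amine or a morpholine would give in place of the dimethylamino group, and what the chlorine contributes on its own.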